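The source may report more compounds than this note shows. Statements on the series, on what has been measured and on what is new or still open speak of the compounds shown alone.

In a functional assay on MCF7 cells (Homo sapiens) for inhibition (a lower number here means a stronger inhibitor, a higher number a weaker inhibitor), compound 1 (`Nc1ccc(-c2nc3ccccc3s2)c(Br)c1`) gives < 0.1 nM, a limit of the assay and not a number. Compound 2 (`Nc1ccc(-c2nc3ccccc3s2)c(I)c1`) gives < 0.1 nM, also a limit. Compound 3 (`Cc1ccc2nc(-c3ccc(N)cc3I)sc2c1`) gives < 0.1 nM, again a limit. The picture is therefore (the limit of < 0.1 nM in this assay, at which 3 of the 3 values shown sit), and compound 2 has no exact place on the scale. Compound 4 (`N#Cc1cc(N)ccc1-c1nc2ccccc2s1`) carries cyano in place of iodo on an aromatic carbon. Among the measured compounds shown here, two measured steps bear on this change, iodo in place of bromo, a step that the two limits leave unreadable from compound 1 to compound 2, and methyl in place of hydrogen, a step that the two limits leave unreadable from compound 2 to compound 3, and neither has a readable size. Only a modest loss in this assay is expected, towards a weaker inhibitor, and the estimated change is an at least 3.0-fold higher number from compound 2 to compound 4 (0.47 log units; beyond the scatter). For compound 4 the expected value is 0.3 nM, with an estimated range of 0.05 nM to 5 nM.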

Compound 4, half-maximal inhibitory concentration: < 10 nM
Compound 4: only a limit was reported; the forecaster's own chance of this, stated with the estimate: 45%; the middle value does not contradict the limit.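

Among the compounds shown here, compound 1, compound 2 and compound 4 all carry only limits in this assay, so no step to compound 4 can be read. The compounds shown leave open what size of change cyano brings in place of iodo or bromo.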